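A few compounds are considered here, and "the series" means these few. Any claim that something is new, unique, unknown or untested is made for them only; others in the source may bear on it.

Working notes on the series. In an assay on Cerebral cortex (strain Sprague-Dawley) for displacement of a labelled ligand from Neuronal acetylcholine receptor; alpha4/beta2 (Rattus norvegicus) (on this read-out lower numbers stand for stronger inhibition and higher numbers for weaker inhibition), compound 1 `CN1CCC[C@H]1[C@H]1COc2ccc(O)cc2O1` gives 421 nM. Compound 2 `Oc1ccc2c(c1)O[C@H]([C@H]1CCCN1)CO2` gives 1300 nM in this assay, the highest of the two numbers recorded so far; its nearest neighbour is compound 1, whose number is lower by an amount that lies beyond the scatter. Within the data shown here, no single-point step between compound 1 and compound 2 is tabulated, so only the two numbers themselves are noted.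

Compound 3 `Oc1ccc2c(c1)O[C@@H]([C@@H]1CCCN1)CO2` has not been measured in this assay. Its relation to compound 2 is the two compounds have the same atoms and bonds and differ only in configuration as drawn: 2 of 2 stereo elements differ (all stereocentres are inverted: mirror images); a stereocentre at a saturated ring carbon is drawn R in compound 2 and S in compound 3; a stereocentre at a saturated ring carbon is drawn R in compound 2 and S in compound 3. Among the measured compounds shown here, no measured pair in this set shows what inverting both stereocentres does, so the size of the step is an open question. For compound 3 the number is expected to move upward, with a step of a 2.3-fold higher number from compound 2 to compound 3 (0.36 log units; beyond the scatter) taken as a working guess and a wide range. Compound 3 is estimated at 3000 nM, within 600 nM to 15000 nM.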

Compound 3, inhibition constant: 1200 nM
The estimate for compound 3 lay 2.5-fold (0.40 log units) above the measured number; the range from low to high includes it.
By their numbers in this assay, from the lowest: compound 1; then compounds 3 and 2 (each within the scatter of the next).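

In this assay, inverting both stereocentres gives a 1.1-fold lower number from compound 2 to compound 3 (0.03 log units; within the scatter), so this read-out does not separate the two mirror images. This comparison isolates configuration alone: the fact that compounds 2 and 3 differ only in the configuration as drawn. The series also gains its first step at the ring nitrogen, where hydrogen in place of methyl on an amine nitrogen in a ring gives a 2.9-fold higher number from compound 1 to compound 3 (0.45 log units; beyond the scatter), a modest step beyond the scatter.

Going by these compounds, it remains open whether inverting only one of the two stereocentres would also leave the number within the scatter, and whether the methyl step would be the same size in the mirror-image compounds. Also open, on these data alone, is how an ethyl group or a longer chain on the ring nitrogen would compare with methyl, or a methoxy group with the hydroxyl on the shared core.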